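The source may report more compounds than this note shows. Statements on the series, on what has been measured and on what is new or still open speak of the compounds shown alone.

Of the compounds shown here, three have so far been measured in an ADME assay on the whole organism for inhibition, with Echinochloa crus-galli var. formosensis as the target, with a stated time of 4 days; on this read-out higher numbers stand for weaker inhibition and lower numbers for stronger inhibition. Compound 1 `CC(C)N(c1nc(Cl)nc(N[C@@H](C)c2ccccc2)n1)C(C)C` gives 110 nM, the lowest of the three numbers. Compound 3 `CC(C)N(c1nc(Cl)nc(N[C@H](C)c2ccccc2)n1)C(C)C` gives 6610 nM, and compound 2 `CCCN(C)c1nc(Cl)nc(N[C@H](C)c2ccccc2)n1` gives 9770 nM. The step of a 60-fold higher number from compound 1 to compound 3 (1.78 log units; beyond the scatter) is a large one, and it rests on (the fact that compounds 1 and 3 differ only in the configuration as drawn). By contrast, the step of a 1.5-fold lower number from compound 2 to compound 3 (0.17 log units; within the scatter) shows that exchanging one amino group for another on the aromatic carbon left the number essentially where it was.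

Compound 4 `CCN(CC)c1nc(Cl)nc(N[C@@H](C)c2ccccc2)n1` has not yet been measured. It differs from compound 1 in one place: diethylamino in place of diisopropylamino on an aromatic carbon. Among the compounds with values here, the only measured step that bears on this is the one from compound 2 to compound 3, where an amino group was exchanged on the same aromatic carbon and the result stayed within the scatter. The same kind of exchange here is therefore expected to bring no step beyond the scatter in this assay. Compound 4 is expected to give about 150 nM, with a range from 50 nM to 500 nM. This corresponds to an expected step of a 1.4-fold higher number from compound 1 to compound 4 (0.13 log units; within the scatter).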

Compound 4, half-maximal inhibitory concentration: 257 nM
Compound 4: the middle estimate sits 1.7-fold (0.23 log units) below what was measured, within the range that was stated.
By their numbers in this assay, from the lowest: compound 1; then compound 4; then compounds 3 and 2 (each within the scatter of the next).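

In this assay, the exchange of diisopropylamino for diethylamino on this aromatic carbon brings a 2.3-fold higher number from compound 1 to compound 4 (0.37 log units; beyond the scatter). With the stereocentre drawn as in compound 1, the amino group at this position therefore moves the number, whereas a 1.5-fold lower number from compound 2 to compound 3 (0.17 log units; within the scatter) showed no such movement for a different amino pair with the stereocentre drawn the other way. This movement is still small beside a 60-fold higher number from compound 1 to compound 3 (1.78 log units; beyond the scatter), and nothing given here accounts for it.

On these data alone, it remains open how dimethylamino, dipropylamino or a cyclic amine such as piperidine would behave on this aromatic carbon. As far as these compounds go, it is also open whether diethylamino in place of diisopropylamino would give a comparable step with the stereocentre drawn as in compound 3.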